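The compounds below may be only part of what the source reports. "The series", "measured", "known", "first", "only" and "open" are said of these compounds alone.

Measured so far:
Compound 1, `O=S(=O)(c1ccc(Cl)cc1)N1CCc2n[nH]cc2C1CO`, gives 84%.
Compound 2, `O=S(=O)(c1ccc(Cl)cc1)N1Cc2c[nH]nc2CC1c1cncnc1`, gives 67%.
Compound 3, `CC[C@H]1Cc2n[nH]cc2[C@@H](c2ccc(Cl)cc2)N1S(=O)(=O)c1ccc(Cl)cc1`, gives 10%.

These three numbers come from an ADME assay on microsomes from liver (Homo sapiens) for metabolic stability, using NADPH, with a stated time of 30 min, in the presence of a further agent that is not named here; a lower number here means that less of the compound is left, a higher number that more of the compound is left. Among them compound 1 stands highest: the gap to compound 2 lies beyond the usual scatter of repeated measurements, and the gap to compound 3 is far wider still. Compound 1 is therefore the most stable of the three in this assay.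

Compound 4, `CN(C)C(=O)OCC1c2c[nH]nc2CCN1S(=O)(=O)c1ccc(Cl)cc1`, is a new compound, not yet measured. Next to compound 1 it shows one change: dimethylcarbamoyl in place of hydrogen on an oxygen on a saturated carbon. Among the compounds with values here, none of the measured compounds shows this same change, so no measured step can be used to judge its effect; the expectation rests on compound 1 alone. Because compound 1 gives 84%, there is room for the number to fall, and a moderate drop is expected, a step of a number 24 percentage points lower from compound 1 to compound 4 (beyond the scatter), which would take compound 4 beyond the scatter but leave it well above compound 3. Compound 4 is estimated at 60%, within a range of 35% to 85%.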

Compound 4, percent of the compound remaining: 15%
For compound 4 the middle estimate is 45 percentage points above the measured one; the whole stated range lies above it.
By their numbers in this assay, from the lowest: compounds 3 and 4 (each within the scatter of the next); then compound 2; then compound 1.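

In this assay this position proves sensitive to what is placed on it. Putting dimethylcarbamoyl in place of hydrogen on the oxygen, which turns hydroxy into (dimethylcarbamoyl)oxy, gives a number 69 percentage points lower from compound 1 to compound 4 (beyond the scatter) and so a large step beyond the scatter. Within the data shown here, this is the first step here between two compounds that differ in one place, so for the first time a change in the number can be tied to a single change in structure, which the earlier compounds could not do. No measurement at hand accounts for the size of this step.

From the compounds shown here alone, whether a smaller group on the same oxygen, such as methyl or acetyl, would bring a similar fall remains open. So does the outcome of putting an amine or a carboxylic acid in place of the hydroxy.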